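Fluoro to Chloro on the Aryl Amine: An Expectation

A few compounds are considered here, and "the series" means these few. Any claim that something is new, unique, unknown or untested is made for them only; others in the source may bear on it.

Among the measured compounds shown here, compound 2 `COc1ccc(C(=O)c2sc(Nc3ccc(F)cc3)c(C(=O)O)c2C)cc1` holds the only number reported so far: in a functional assay, with a stated time of 150 min, tested at 35 ug/mL (on this read-out lower numbers stand for a weaker effect and higher numbers for a stronger effect at the one concentration tested), compound 2 gives 12.8%. For the measured compounds named here, compound 1 `COc1ccc(C(=O)c2sc(Nc3ccc(C)cc3)c(C(=O)O)c2C)cc1` is recorded in this assay as "not active" (no number reported), without a figure, so no step between measured compounds can be drawn. Going by the values given here, compound 3 `COc1ccc(C(=O)c2sc(Nc3ccc(Cl)cc3)c(C(=O)O)c2C)cc1` remains to be tested. chloro in place of fluoro on an aromatic carbon No measured pair speaks to this exchange, so the expected step of a number 2.2 percentage points higher from compound 2 to compound 3 (within the scatter) is small, in no particular direction, and not beyond the usual scatter. Compound 3 is accordingly estimated at 15% in this assay, with a range from 0% to 35%.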

Compound 3, a percentage reported as activity, at one concentration (the size of the read-out at that concentration, not a potency): "not active" (no number reported)
No number was reported for compound 3; there is nothing to compare the estimate with.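

Among the compounds shown here, compound 3, like compound 1, carries no number, and no step from compound 2 to compound 3 can be read. The compounds shown leave open how far changing the para substituent shifts this activity. No measurement shown bears on the result.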